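Swapping a tert-Butyl Ester for a Benzyl Ester

A few compounds are considered here, and "the series" means these few. Any claim that something is new, unique, unknown or untested is made for them only; others in the source may bear on it.

Compound 2 `CC1=C(C(=O)OC(C)(C)C)C(c2ccoc2)NC(=O)N1C` stands lowest of the two measured compounds in an assay on membranes from HEK293 cells for displacement of a labelled ligand from adenosine receptor A2b (Homo sapiens), read by scintillation counting, with a stated time of 30 min, tested at 1 uM (on this read-out lower numbers stand for less inhibition and higher numbers for more inhibition at the one concentration tested (going by the name of the read-out)), where compound 2 gives 16%. The other measured compound, compound 1 `CC1=C(C(=O)OCc2ccccc2)C(c2ccco2)NC(=O)N1C`, gives 41% in this assay, a number that lies beyond the usual scatter above compound 2. These two compounds differ from each other in more than one place, so their values show only where each of them stands. Compound 3 `CC1=C(C(=O)OCc2ccccc2)C(c2ccoc2)NC(=O)N1C` has not yet been tested. It is compound 2 with a single change: benzyl in place of tert-butyl on an oxygen next to a carbonyl group. The benzyl ester is also the group carried by compound 1, while the rest of compound 3 matches compound 2. Because compound 1 reaches 41% with a benzyl ester, a rise in this assay for compound 3 relative to compound 2 is expected, though the second difference between compounds 1 and 2 leaves its size uncertain. The expected step is a number 14 percentage points higher from compound 2 to compound 3 (beyond the scatter). Compound 3 is estimated at 30%, within a range from 12% to 48%.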

Compound 3, a percentage reported as inhibition, at one concentration (the size of the read-out at that concentration, not a potency): 49%
Compound 3: the middle estimate sits 19 percentage points below what was measured, outside the stated range (above it).
By their numbers in this assay, from the lowest: compound 2; then compounds 1 and 3 (each within the scatter of the next).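

In this assay the ester position now has a comparison in one place: with the furan-3-yl group and the rest of the core unchanged, benzyl in place of tert-butyl on an oxygen next to a carbonyl group gives a number 33 percentage points higher from compound 2 to compound 3 (beyond the scatter) and so shows that this position can strongly change the read-out. The second single change, furan-3-yl in place of furan-2-yl on a saturated ring carbon, gives a number 8 percentage points higher from compound 1 to compound 3 (within the scatter) with the benzyl ester kept in both compounds. Among these three compounds, then, the ester change is the one of the two single changes whose step lies beyond the scatter, although the furan change has been seen only with a benzyl ester.

Nothing available here explains why the benzyl ester gives the higher number. Still open, as far as these compounds go, is whether the rise depends on the aromatic ring of benzyl or would also appear with a cyclohexylmethyl ester, a longer phenethyl ester or an amide in place of the ester oxygen.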